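Benzyl for isopropyl on sulfur: cytotoxicity notes

The source may hold more compounds than are shown below. What is called first, only, known or untested is meant among the compounds shown, and "the series" means these compounds.

Compound 1 `Nc1nc(OCC(F)(F)F)c2ncn(/C=C3/CC3(CO)CO)c2n1` gives > 20000 nM in an ADME assay on CCRF-HSB-2 cells (Homo sapiens) for cytotoxicity, with a stated time of 7 days (on this read-out higher numbers stand for lower toxicity in this test and lower numbers for higher toxicity in this test), as a limit
Compound 2 `CC(C)Sc1nc(N)nc2c1ncn2/C=C1/CC1(CO)CO` gives 94000 nM in this assay as a number

Among the compounds with values here, compound 2 holds the only number in this set. Within the data shown here, the one measured step that the limit leaves unreadable from compound 1 to compound 2 has no readable size and offers no guide to the next change. Compound 3 `Nc1nc(SCc2ccccc2)c2ncn(/C=C3/CC3(CO)CO)c2n1` differs from compound 2 by benzyl in place of isopropyl on a sulfur and reads benzyl in place of isopropyl on a sulfur. With compound 2 at 94000 nM as the sole anchor in this assay no shift beyond the scatter is expected. The expected step of a 1.3-fold lower number from compound 2 to compound 3 (0.13 log units; within the scatter) has no firm direction. Compound 3 is estimated at 70000 nM with an expected range from 15000 nM to 200000 nM for now.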

Compound 3, half-maximal cytotoxic concentration: > 100000 nM
Compound 3 was reported as a limit; the forecaster's own chance of this, stated with the estimate: 40%; middle value at least 1.4-fold (0.15 log units) away from the limit.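

In this assay, benzyl in place of isopropyl on a sulfur gives an at least 1.0-fold higher number from compound 2 to compound 3 (0.02 log units; that floor lies within the scatter), so the added six-membered aromatic ring brings no lower number at this sulfur. Compound 3 is reported only as a limit: the limit of > 100000 nM in this assay, at which 1 of the 3 values shown sits.

The step from compound 1 to compound 3 cannot be read, as both values are limits. Going by these compounds, how far the number of compound 3 lies beyond its limit stays open, as does whether an amine in place of benzylsulfanyl on the aromatic carbon would give a lower number.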